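From 2-fluorobenzyl to 4-fluorobenzyl: A Single Swap

This account rests on a few compounds, and the source may have more. Where it says the series, first, only, none or still open, it means among the compounds named here.

In a functional assay on A-375 cells (Homo sapiens) for antiproliferative activity, read by MTT assay, with a stated time of 24 h (on this read-out lower numbers stand for stronger inhibition and higher numbers for weaker inhibition), compound 1 `COc1cc(OC)c(-c2coc3cc(OCC(=O)c4cccc(C(F)(F)F)c4)ccc3c2=O)cc1OC` gives > 10000 nM, which is a limit of the assay and not a number. For the measured compounds named here, compound 2 `COc1cc(OC)c(-c2coc3cc(OCc4ccccc4F)ccc3c2=O)cc1OC` gives 2100 nM, the only actual number so far. Compound 3 `COc1cc(OC)c(-c2coc3cc(OCc4ccc(F)cc4)ccc3c2=O)cc1OC` has 4-fluorophenyl in place of 2-fluorophenyl on a saturated chain carbon bound to an oxygen on an aromatic ring. Going by the values given here, the one measured step, an at least 4.7-fold lower number from compound 1 to compound 2 (0.67 log units; beyond the scatter), involved a different swap and bears only loosely on this one. The expected change is therefore none beyond the scatter, with a 1.1-fold lower number from compound 2 to compound 3 (0.02 log units; within the scatter). The estimate for compound 3 is 2000 nM, with a range of 700 nM to 6000 nM.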

Compound 3, half-maximal inhibitory concentration: 1720 nM
The estimate for compound 3 lay 1.2-fold (0.07 log units) above the measured number, and the stated range covers the measured number.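

The swap of 2-fluorobenzyl for 4-fluorobenzyl gives a 1.2-fold lower number from compound 2 to compound 3 (0.09 log units; within the scatter), so in this assay these two groups cannot be told apart at this place. A second fluorobenzyl compound also shows a clear gain over the carbonyl-bearing compound 1, with an at least 5.8-fold lower number from compound 1 to compound 3 (0.76 log units; beyond the scatter). That step is only a bound, because compound 1 gives a limit of the assay and not a number: the limit of > 10000 nM in this assay, at which 1 of the 3 values shown sits.

Still open, from the compounds shown here alone, is how a plain benzyl, with no fluorine, would compare at this place. So is the effect of a benzyl carrying an amine or a carboxylic acid.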